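The source may hold more compounds than are shown below. What is called first, only, known or untested is meant among the compounds shown, and "the series" means these compounds.

Compound 1 `C=C(CCO)C(=O)Nc1ccccc1`: in an ADME assay for pharmacokinetics, read by LC-MS, in phosphate buffer, with a stated time of 120 min, at pH 7.4, tested at 1 uM, in the presence of a further agent that is not named here (a higher number here means that the compound lasts longer, a lower number that the compound disappears faster), compound 1 gives > 8.53 h, which is a limit of the assay rather than a number.
Compound 2 `CN(C)CC/C=C/C(=O)Nc1ccccc1`: in this assay compound 2 gives 7.38 h.
Compound 3 `C=C(C(=O)Nc1ccccc1)C(F)(F)F`: in this assay compound 3 gives 0.25 h.

Of the two numbers shown, compound 2 stands highest, with compound 3 its nearest neighbour at a gap beyond the scatter. For the measured compounds named here, the only measured single-point step, an at least 34-fold lower number from compound 1 to compound 3 (1.53 log units; beyond the scatter), alters a group on a double-bonded chain carbon bound to a carbonyl carbon and leaves untouched the part changed here. Compound 4 `CN(C)C/C=C/C(=O)Nc1ccccc1` differs from compound 2 by dimethylamino in place of (dimethylamino)methyl on a saturated chain carbon bound to a double-bonded chain carbon. Going by the values given here, no measured step bears on this change, so the expectation rests on compound 2 alone, and no step beyond the scatter is expected in this assay. Compound 4 is therefore estimated at 6 h, between 2.5 h and 14 h, which means an expected step of a 1.2-fold lower number from compound 2 to compound 4 (0.09 log units; within the scatter).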

Compound 4, half-life: 1.93 h
Beside the measured number, compound 4's estimate is 3.1-fold (0.49 log units) above it, outside the stated range (below it).
By their numbers in this assay, from the lowest: compound 3; then compound 4; then compound 2. At a limit, above all of these: compound 1.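

In this assay, dimethylamino in place of (dimethylamino)methyl on a saturated chain carbon bound to a double-bonded chain carbon gives a 3.8-fold lower number from compound 2 to compound 4 (0.58 log units; beyond the scatter), a modest step. The half-life at this place therefore responds to the length of the chain carrying the amine, which the earlier step, made at another place, could not show. Nothing measured here accounts for this step. The compounds shown leave open whether a longer chain would continue this trend, and whether a morpholine in place of the dimethylamino group would behave alike.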